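Replacing 4-methoxyphenyl with methoxycarbonyl in compound 3

The source may report more compounds than this note shows. Statements on the series, on what has been measured and on what is new or still open speak of the compounds shown alone.

compound 1 (`CCCOc1ccc(S(=O)(=O)N2CCC(N3CCC(C)CC3)CC2)cc1`): 452 nM
compound 2 (`CC1CCN(C2CCN(S(=O)(=O)c3ccc(-c4ccc(Cl)cc4)cc3)CC2)CC1`): 105 nM
compound 3 (`COc1ccc(-c2ccc(S(=O)(=O)N3CCC(N4CCC(C)CC4)CC3)cc2)cc1`): 263 nM

In a functional assay on DLD-1 cells (Homo sapiens) for antiproliferative activity, read by CellTiter-Glo, with a stated time of 72 h (a higher number here means a weaker inhibitor, a lower number a stronger inhibitor), the value of compound 3 (263 nM) lies within the scatter of that of compound 1 (452 nM). Methoxy in place of chloro separates it from its nearest relative (a 2.5-fold higher number from compound 2 to compound 3 (0.40 log units; beyond the scatter)). Compound 4 (`COC(=O)c1ccc(S(=O)(=O)N2CCC(N3CCC(C)CC3)CC2)cc1`) carries methoxycarbonyl in place of 4-methoxyphenyl on an aromatic carbon. Within the data shown here, no measured step makes this exact exchange. The closest are the two that replace propoxy with an aryl group, one of them within the scatter (a 1.7-fold lower number from compound 1 to compound 3 (0.24 log units; within the scatter)) and the other beyond it (a 4.3-fold lower number from compound 1 to compound 2 (0.63 log units; beyond the scatter)). Read in reverse, they suggest that removing the outer aromatic ring may raise the number, though propoxy is only a rough stand-in for methoxycarbonyl. A modest move to a higher number is therefore expected in this assay (a 2.3-fold higher number from compound 3 to compound 4 (0.36 log units; beyond the scatter)). For compound 4 the estimated value is 600 nM (expected range 200 nM to 1800 nM).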

Compound 4, half-maximal inhibitory concentration: > 5000 nM
Compound 4: no number, only a limit; the forecaster's own chance of this, stated with the estimate: 5%; middle value at least 8.3-fold (0.92 log units) from the limit.
By their numbers in this assay, from the lowest: compound 2; then compounds 3 and 1 (each within the scatter of the next). At a limit, above all of these: compound 4.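

Compound 4 has no number in this assay, only a limit of the assay: the limit of > 5000 nM in this assay, at which 1 of the 4 values shown sits.

Even so, each step into it is large and beyond the scatter (an at least 19-fold higher number from compound 3 to compound 4 (1.27 log units; beyond the scatter); an at least 47-fold higher number from compound 2 to compound 4 (1.67 log units; beyond the scatter); an at least 11-fold higher number from compound 1 to compound 4 (1.04 log units; beyond the scatter)), so the group on this aromatic carbon, para to a large group, can decide whether a number is reached at all. Among these compounds, compound 1, with propoxy and likewise no outer aromatic ring, gives 452 nM, so the absence of that ring does not by itself leave a compound without a number, and the earlier compounds gave no sign that a small group here could cost this much.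

The compounds shown leave open how an amide, a carboxylic acid or a nitrile would fare at this position. They also leave open whether a methoxycarbonyl group carried on an outer phenyl ring would keep a measurable number.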